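Linker extension in a fluorophenyl-pyrazole hydroxamic acid series

The source may hold more compounds than are shown below. What is called first, only, known or untested is meant among the compounds shown, and "the series" means these compounds.

Measured compounds:
compound 1 `O=C(CCCCCNC(=O)c1cc(-c2ccc(F)cc2)[nH]n1)NO`: 47600 nM
compound 2 `CCCc1cc(-c2ccc(F)cc2)n(Cc2ccc(C(=O)NO)cc2)n1`: 6660 nM
compound 3 `CCc1cc(-c2ccc(F)cc2)n(Cc2ccc(C(=O)NO)cc2)n1`: 7760 nM

In a functional assay on HepG2 cells (Homo sapiens) for antiproliferative activity, read by MTT assay, with a stated time of 96 h (a lower number here means a stronger inhibitor of growth, a higher number a weaker inhibitor of growth), compound 1 gives the highest number of the three. Compound 3 gives a number well below it, and compound 2 lower still; both gaps lie beyond the scatter. Going by the values given here, the only measured step, a 1.2-fold higher number from compound 2 to compound 3 (0.07 log units; within the scatter), concerns an alkyl group on the core and lies within the scatter.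

Compound 4 `O=C(CCCCCCNC(=O)c1cc(-c2ccc(F)cc2)[nH]n1)NO` differs from compound 1 by (hydroxycarbamoyl)methyl in place of hydroxycarbamoyl on a saturated chain carbon, five bonds along the chain from an amide-type nitrogen. Among the compounds with values here, no measured pair shows this chain lengthening, so the step of a 1.2-fold higher number from compound 2 to compound 3 (0.07 log units; within the scatter) offers only indirect guidance, and it was small. Little change beyond the scatter is therefore expected in this assay. Compound 4 is estimated at 35000 nM (range 12000 nM to 100000 nM), an expected step of a 1.4-fold lower number from compound 1 to compound 4 (0.13 log units; within the scatter).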

Compound 4, concentration for 50% growth inhibition: 23200 nM
Compound 4: the middle estimate sits 1.5-fold (0.18 log units) above what was measured, within the range that was stated.
By their numbers in this assay, from the lowest: compounds 2 and 3 (each within the scatter of the next); then compound 4; then compound 1.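

In this assay, going by these compounds alone, the change from hydroxycarbamoyl to (hydroxycarbamoyl)methyl gives a 2.1-fold lower number from compound 1 to compound 4 (0.31 log units; beyond the scatter) and is the first measured step on this chain, five bonds along it from the amide-type nitrogen. The step is modest but lies beyond the scatter, so this position responds to a change of this kind, unlike the alkyl change on the core in a 1.2-fold higher number from compound 2 to compound 3 (0.07 log units; within the scatter). Nothing measured here accounts for the shift.

One step cannot show whether a longer chain such as 2-(hydroxycarbamoyl)ethyl would continue in the same direction. As far as these compounds go, how a carboxylic acid in place of the hydroxycarbamoyl end would read also remains open.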